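The compounds below may be only part of what the source reports. "The series", "measured", "known", "first", "only" and "open" are said of these compounds alone.

Measured compounds:
- compound 1, `C1=NCC(CC2=Cc3ccccc3CC2)N1`: 50.1 nM
- compound 2, `Fc1ccc2c(c1)C=C(CC1CN=CN1)CC2`: 50.1 nM
- compound 3, `C1=C(Cc2c[nH]cn2)CCc2ccccc21`: 794 nM

In a functional assay for binding affinity to Norepinephrine transporter (Rattus norvegicus), read by radioligand binding, in the presence of a further agent that is not named here (on this read-out lower numbers stand for stronger inhibition and higher numbers for weaker inhibition), compound 1 gives 50.1 nM and stands level with compound 2, the two together giving the lowest numbers of the three; compound 3, with 794 nM, lies furthest from it. The step of no change at the digits printed from compound 1 to compound 2 (within the scatter) shows that fluoro on the aromatic carbon leaves the number where it was. The step of a 16-fold higher number from compound 1 to compound 3 (1.20 log units; beyond the scatter) shows that exchanging the five-membered non-aromatic ring for the aromatic one costs a great deal.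

Compound 4, `CC1(CC2=Cc3ccccc3CC2)CN=CN1`, differs from compound 1 by methyl in place of hydrogen on a saturated ring carbon. Among the compounds with values here, neither measured step touches this saturated ring carbon, so no step bears directly on it. The ring that matters so much in the step from compound 1 to compound 3 is kept intact in compound 4, so the change is expected to be small, at most a modest weakening. Compound 4 is expected to give 100 nM in this assay, within 30 nM to 400 nM, which means an estimated step of a 2.0-fold higher number from compound 1 to compound 4 (0.30 log units; within the scatter).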

Compound 4, inhibition constant: 316 nM
Compound 4: the middle estimate sits 3.2-fold (0.50 log units) below what was measured, and the stated range covers the measured number.
By their numbers in this assay, from the lowest: compounds 1 and 2 (each within the scatter of the next); then compound 4; then compound 3.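

In this assay, the saturated ring carbon of the five-membered non-aromatic ring proves sensitive to substitution: methyl in place of hydrogen there gives a 6.3-fold higher number from compound 1 to compound 4 (0.80 log units; beyond the scatter). The earlier steps shown here showed a large loss only when that ring itself was exchanged for the aromatic one, whereas here the ring is kept and a single added carbon is enough to move the number beyond the scatter. That sets this position apart from the aromatic carbon that took fluoro in no change at the digits printed from compound 1 to compound 2 (within the scatter), and no measurement at hand accounts for the weakening.

The compounds shown leave open how an ethyl group, a hydroxyl or an amine on this saturated ring carbon would read. They also leave open whether methyl at this carbon would have the same effect alongside the fluoro of compound 2.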